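Swapping cyano for nitro on compound 1

A few compounds are considered here, and "the series" means these few. Any claim that something is new, unique, unknown or untested is made for them only; others in the source may bear on it.

compound 1 `Cc1cccc(C(=O)n2cc(C#N)c3cccnc32)c1`: 1.9 h
compound 2 `Cc1ccc(C(=O)n2cc(C#N)c3cccnc32)cc1`: 2.6 h
compound 3 `CCCCC(=O)n1cc(C#N)c2cccnc21`: 1.9 h

These three half-lives come from a physicochemical assay for metabolic stability, read by spectrophotometry, in phosphate buffer, at 25 degrees C, at pH 7.3; on this read-out higher numbers stand for a longer-lived compound and lower numbers for a shorter-lived compound. Compound 1 stands level with compound 3 at the digits shown, and its distance from compound 2 lies within the scatter, so the three cannot be told apart. Compound 4 `Cc1cccc(C(=O)n2cc([N+](=O)[O-])c3cccnc32)c1` keeps the rest of compound 1 but has nitro in place of cyano on an aromatic carbon. Among the compounds with values here, no measured pair shows this exchange, so the direction is a judgement only. The expected change is a small fall, a 1.4-fold lower number from compound 1 to compound 4 (0.13 log units; within the scatter), not clearly beyond the scatter. For compound 4 the estimated half-life is 1.4 h, with an expected range of 0.6 h to 3.2 h.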

Compound 4, half-life: 0.4 h
Compound 4: middle estimate off by 3.5-fold (0.54 log units), on the high side, and the stated range ends above it.
By their numbers in this assay, from the lowest: compound 4; then compounds 1, 3 and 2 (each within the scatter of the next).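

In this assay, within the data shown here, nitro in place of cyano on an aromatic carbon gives a 4.8-fold lower number from compound 1 to compound 4 (0.68 log units; beyond the scatter) and so shows that the half-life responds to the group at this position, which the earlier compounds, all carrying cyano there, could not show. This rests on a single step from one background, and nothing available here bears on why it occurs. From the compounds shown here alone, whether compound 2 and compound 3 would respond alike to nitro remains open, as does the effect of an amine or a carboxylic acid on this carbon.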